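The source may report more compounds than this note shows. Statements on the series, on what has been measured and on what is new or still open speak of the compounds shown alone.

Compound 3 `COC(=O)CC/C(C)=C/Cc1c(OC)c(C)c2c(c1OCC#CCN1CCN(C(=O)C3COc4ccccc4O3)CC1)C(=O)OC2` is one of three close analogues tested in a functional assay on HT-29 cells (Homo sapiens) for inhibition, read by sulforhodamine B assay; on this read-out lower numbers stand for stronger inhibition and higher numbers for weaker inhibition. In this assay compound 3 gives > 50000 nM, which is a limit of the assay and not a number. Compound 1 `COC(=O)CC/C(C)=C/Cc1c(OC)c(C)c2c(c1OCC#CCN1CCN(c3ccc(C)cc3)CC1)C(=O)OC2` carries a 4-methylphenyl on the same amine nitrogen in a ring, and in this assay compound 1 gives > 50000 nM, again a limit. Compound 2 `COC(=O)CC/C(C)=C/Cc1c(OC)c(C)c2c(c1OCC#CCN1CCN(C(c3ccccc3)c3ccccc3)CC1)C(=O)OC2` bears a different substituent on that nitrogen, and in this assay compound 2 gives > 50000 nM, also a limit. The step that the two limits leave unreadable from compound 1 to compound 3 therefore cannot be read, since (the limit of > 50000 nM in this assay, at which 3 of the 3 values shown sit). Compound 4 `COC(=O)CC/C(C)=C/Cc1c(OC)c(C)c2c(c1OCC#CCN1CCN(c3ccccc3F)CC1)C(=O)OC2` differs from compound 3 in one place: 2-fluorophenyl in place of (2,3-dihydro-1,4-benzodioxin-2-yl)carbonyl on an amine nitrogen in a ring. No readable measured step bears on this change, and all three values sit at the same limit, so no step beyond the scatter is expected in this assay. For compound 4 the estimate in this assay is 50000 nM, with a range from 15000 nM to 200000 nM, and a limit rather than a number is expected. The expected step is a number no higher from compound 3 to compound 4 (the limit leaves the size open).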

Compound 4, half-maximal inhibitory concentration: > 50000 nM
Compound 4 gave a limit, no number; the forecaster's own chance of this, stated with the estimate: 85%; the middle value sits exactly at the limit.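

Compound 4 gives only a limit in this assay, as do compound 1 and compound 3, so no new step can be read from it: the limit of > 50000 nM in this assay, at which 4 of the 4 values shown sit. The compounds shown leave open whether any substituent on this amine nitrogen would give a measurable value in this assay.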